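This account rests on a few compounds, and the source may have more. Where it says the series, first, only, none or still open, it means among the compounds named here.

Working notes on the series. In a functional assay on HeLa cells (Homo sapiens) for antiproliferative activity, read by sulforhodamine B assay (on this read-out higher numbers stand for weaker inhibition of growth and lower numbers for stronger inhibition of growth), compound 1 (`O[C@H]1CO[C@H](COCc2ccccc2)[C@@H](OCc2ccccc2)[C@@H]1OCc1ccccc1`) gives > 50000 nM as a limit of the assay and not a number. Compound 2 (`CCCC[C@@H]1O[C@H](COCc2ccccc2)[C@@H](OCc2ccccc2)[C@H](OCc2ccccc2)[C@H]1O`) gives > 50000 nM as a limit as well. Compound 3 (`CC(C)C[C@@H]1O[C@H](COCc2ccccc2)[C@@H](OCc2ccccc2)[C@H](OCc2ccccc2)[C@H]1O`) gives > 50000 nM as a limit as well. Compound 1 thus stands with the other two at the limit of > 50000 nM in this assay, at which 3 of the 3 values shown sit, and the three cannot be ordered.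

Compound 4 (`O[C@@H]1[C@@H](OCc2ccccc2)[C@H](OCc2ccccc2)[C@@H](COCc2ccccc2)O[C@@H]1CC1CCCCC1`) differs from compound 1 by cyclohexylmethyl in place of hydrogen on a saturated ring carbon, next to the ring oxygen (cyclohexylmethyl in place of hydrogen on a saturated ring carbon). The closest measured changes likewise add a group to the shared core. Butyl gives a step that the two limits leave unreadable from compound 1 to compound 2 and isobutyl gives a step that the two limits leave unreadable from compound 1 to compound 3 while the change between these two groups gives a step that the two limits leave unreadable from compound 2 to compound 3 in turn. None of these steps has a readable size, but neither group brought a number within reach of this assay.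

No step beyond the scatter is therefore expected, and no direction can be assigned. The expected step is a number no higher from compound 1 to compound 4 (the limit leaves the size open) on this estimate. Compound 4 is estimated at 50000 nM with a range from 20000 nM to 100000 nM and is expected to be reported most likely as a limit again.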

Compound 4, concentration for 50% growth inhibition: > 50000 nM
Compound 4: a limit, no number (the forecaster's own chance of this, stated with the estimate: 80%); the middle value sits exactly at the limit.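

In this assay compound 4 gives > 50000 nM, again a limit of the assay and not a number. No step from compound 1 to compound 4 can be read, and the series stays at a single mark: the limit of > 50000 nM in this assay, at which 4 of the 4 values shown sit.

The compounds shown leave open how these four rank and whether any group on this saturated ring carbon can give a number in this assay.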